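The compounds below may be only part of what the source reports. "The series", "measured", "known", "first", "only" and "open" are said of these compounds alone.

The measured compounds:
Compound 1 `COc1cc(C(=O)/C=C/c2cc(-c3cc(OC)c(OC)c(OC)c3)n3nc(-c4ccccc4)cc3n2)cc(OC)c1OC` gives in an ADME assay on HEK293 cells (Homo sapiens) for antiproliferative activity, read by MTT assay, with a stated time of 24 h (on this read-out lower numbers stand for stronger inhibition and higher numbers for weaker inhibition), a value of >= 100000 nM, which is a limit of the assay and not a number.
Compound 2 `COc1cc(-c2cc(/C=C/C(=O)c3ccc(C)cc3)nc3cc(-c4ccccc4)nn23)cc(OC)c1OC` gives in this assay 50400 nM.
Compound 3 `COc1ccc(-c2cc(/C=C/C(=O)c3ccc(Cl)cc3)nc3cc(-c4ccccc4)nn23)cc1OC` gives in this assay 44100 nM.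

Compound 3 holds the lowest of the two numbers, and compound 2 stands within the scatter of it. Compound 4 `COc1cc(-c2cc(/C=C/C(=O)c3ccc(Cl)cc3)nc3cc(-c4ccccc4)nn23)cc(OC)c1OC` differs from compound 3 by methoxy in place of hydrogen on an aromatic carbon. Going by the values given here, the only step measured so far, an at least 1.9-fold lower number from compound 1 to compound 2 (0.29 log units; that floor lies within the scatter), alters the aryl group on the carbonyl carbon, and its floor lies within the scatter; it does not bear directly on a methoxy added to the other ring. Among the compounds with values here, no measured step sets a direction, so compound 4 is expected to show a 1.1-fold higher number from compound 3 to compound 4 (0.05 log units; within the scatter), nothing beyond the scatter. Compound 4 is estimated at 50000 nM, with a range from 20000 nM to 150000 nM.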

Compound 4, half-maximal inhibitory concentration: >= 100000 nM
Compound 4: no number, only a limit; the forecaster's own chance of this, stated with the estimate: 25%; middle value at least 2.0-fold (0.30 log units) away from the limit.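

In this assay, the change from 3,4-dimethoxyphenyl to 3,4,5-trimethoxyphenyl gives an at least 2.2-fold higher number from compound 3 to compound 4 (0.35 log units; beyond the scatter), the only step shown on this ring, and it points towards weaker inhibition. Chloro in place of methyl on the other aromatic ring gives an at least 1.9-fold higher number from compound 2 to compound 4 (0.29 log units; that floor lies within the scatter), so that comparison sets no firm direction. The step between compound 1 and compound 4 cannot be read, because both values sit at the same limit: the limit of >= 100000 nM in this assay, at which 2 of the 4 values shown sit.

Going by these compounds, the size of the loss stays open, since the reading for compound 4 is a limit and not a number. On these data alone, what a hydroxy or an ethoxy group would do at this position also remains open.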